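Moving from a chlorophenyl to a fluoro-methoxyphenyl arm

This account rests on a few compounds, and the source may have more. Where it says the series, first, only, none or still open, it means among the compounds named here.

Compound 1, `COc1cc(-c2ccnc3cc(-c4ccc(Cl)cc4)nn23)cc(OC)c1OC`: 2320 nM
Compound 2, `Cn1ccc2cc(-c3cc4nccc(-c5ccc(F)cc5)n4n3)ccc21`: 4580 nM
Compound 3, `COc1cc(-c2ccnc3c(-c4ccc(C)cc4)cnn23)cc(OC)c1OC`: > 10000 nM

In a functional assay on MCF7 cells (Homo sapiens) for inhibition, read by CCK-8 assay, with a stated time of 48 h (a lower number here means a stronger inhibitor, a higher number a weaker inhibitor), compound 1 holds the lowest of the two numbers, and compound 2 sits close to it, within the scatter. Compound 3 reaches only (the limit of > 10000 nM in this assay, at which 1 of the 3 values shown sits), a limit and not a number. Compound 4, `COc1ccc(-c2cc3nccc(-c4cc(OC)c(OC)c(OC)c4)n3n2)cc1F`, differs from compound 1 in one place: 3-fluoro-4-methoxyphenyl in place of 4-chlorophenyl on an aromatic carbon. For the measured compounds named here, no pair of measured compounds shows a change of this kind, so no step size is known from the numbers in hand. Compound 4 is therefore expected to land near compound 1, the step of a 1.1-fold higher number from compound 1 to compound 4 (0.03 log units; within the scatter) small and without direction beyond the scatter. The estimate for compound 4 in this assay is 2500 nM, expected to fall between 800 nM and 8000 nM.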

Compound 4, half-maximal inhibitory concentration: 183 nM
For compound 4 the middle estimate is 14-fold (1.14 log units) above the measured one; measured number outside the range, below it.
By their numbers in this assay, from the lowest: compound 4; then compounds 1 and 2 (each within the scatter of the next). At a limit, above all of these: compound 3.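

In this assay the swap gives a 13-fold lower number from compound 1 to compound 4 (1.10 log units; beyond the scatter) and so shows that this position on the five-membered aromatic ring is far from indifferent to the arm it carries. The earlier compounds shown here offered no step at all from which to see this. Nothing measured here gives a reason for the change.

Whether the fluorine, the methoxy group or the two together account for the step remains open. So does how an amine or a carboxylic acid on this arm would fare.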